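One Stereocentre Reversed, from Compound 3 to Compound 4

The source may hold more compounds than are shown below. What is called first, only, known or untested is meant among the compounds shown, and "the series" means these compounds.

Three ureas have been measured so far. Compound 1 `C[C@H](NC(=O)Nc1ccccc1Cl)c1ccccc1` gives 104% in an ADME assay on the whole organism with Oryza sativa as the target, tested at 1 uM; a higher number here means a weaker effect of the compound at the concentration tested, a lower number a stronger effect. Compound 2 `C[C@H](NC(=O)Nc1cccc(Cl)c1)c1ccccc1` gives 99% in this assay, and compound 3 `C[C@@H](NC(=O)Nc1cc(Cl)ccc1Cl)c1ccccc1` gives 100% in this assay. Among these three numbers compound 3 stands second highest; its nearest neighbour is compound 2 and its furthest compound 1, and both gaps lie within the scatter, so none of the three can be called stronger or weaker than another.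

For the measured compounds named here, compound 4 `C[C@H](NC(=O)Nc1cc(Cl)ccc1Cl)c1ccccc1` has not been measured. the two compounds have the same atoms and bonds and differ only in configuration as drawn: 1 of 1 stereo elements differ; a stereocentre at a saturated chain carbon is drawn R in compound 3 and S in compound 4 No step between measured compounds is available, so the expectation rests on the three values sitting close together. In this assay compound 4 is expected to give 100%, between 92% and 108%. The estimated step of no change at the digits printed from compound 3 to compound 4 (within the scatter) is expected to stay within the scatter, in no particular direction.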

Compound 4, a percentage reported as activity, at one concentration (the size of the read-out at that concentration, not a potency): 99%
The estimate for compound 4 lay 1 percentage points above the measured number; low and high end bracket the measured number.
By their numbers in this assay, from the lowest: compounds 2, 4, 3 and 1 (each within the scatter of the next).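

For the compounds shown here, for the first time, compounds differing in one place can be compared, and in this assay reversing the stereocentre gives a number 1 percentage points lower from compound 3 to compound 4 (within the scatter). This pair isolates the stereocentre, with no other change to account for: the fact that compounds 3 and 4 differ only in the configuration as drawn. Chloro in place of hydrogen on an aromatic carbon gives no change at the digits printed from compound 2 to compound 4 (within the scatter) and a number 5 percentage points lower from compound 1 to compound 4 (within the scatter), so neither kind of change separates these ureas.

Still open, going by these compounds, is whether an amine or a carboxylic acid on the aromatic ring, in place of chloro, would move the read-out beyond the scatter. On these data alone, whether the stereocentre would then matter is equally open.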